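The source may report more compounds than this note shows. Statements on the series, on what has been measured and on what is new or still open speak of the compounds shown alone.

Compound 1 `O=C1CSC(c2ccc(F)cc2)N1CCN1CCCCC1` gives 87% in an ADME assay on Vero cells (Chlorocebus sabaeus) for cytotoxicity, read by neutral red uptake, tested at 98 ug/mL; on this read-out higher numbers stand for a weaker effect at the one concentration tested and lower numbers for a stronger effect. Compound 2 `O=C1CSC(c2ccc([N+](=O)[O-])cc2)N1CCN1CCCCC1` gives 87% in this assay, and the step of no change at the digits printed from compound 1 to compound 2 (within the scatter) shows no movement beyond the scatter for nitro in place of fluoro on an aromatic carbon, so compound 1 stands level with compound 2. Compound 3 `O=C1CSC(c2cccc(O)c2)N1CCN1CCCCC1` has not yet been measured; it differs from compound 1 by 3-hydroxyphenyl in place of 4-fluorophenyl on a saturated ring carbon. Among the compounds with values here, only that one step bears on the change, and it was flat. For compound 3 the expected step is no change at the digits printed from compound 1 to compound 3 (within the scatter), none beyond the scatter. Compound 3 is therefore estimated at 87%, within 75% to 97%.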

Compound 3, a percentage reported as activity, at one concentration (the size of the read-out at that concentration, not a potency): 100%
Estimate against measurement, compound 3: 13 percentage points below, outside the stated range (above it).
By their numbers in this assay, from the lowest: compounds 1 and 2 (each within the scatter of the next); then compound 3.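

Putting 3-hydroxyphenyl in place of 4-fluorophenyl on this saturated ring carbon gives a number 13 percentage points higher from compound 1 to compound 3 (beyond the scatter) in this assay, a shift toward a weaker effect. The aromatic group at this position can therefore move the read-out, which the exchange of fluoro for nitro did not show. No measurement here accounts for the shift.

The step changes both the substituent and its place on the phenyl ring, so the compounds shown do not separate the two. A 4-hydroxyphenyl or 3-methoxyphenyl group at this carbon would bear on that question.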